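The compounds below may be only part of what the source reports. "The series", "measured", "known", "first", "only" and "open" are said of these compounds alone.

In a functional assay on HL-60 cells (Homo sapiens) for inhibition, read by CCK-8 assay, with a stated time of 48 h, tested at 20 uM (on this read-out higher numbers stand for more inhibition of growth at the one concentration tested and lower numbers for less inhibition of growth), compound 1 `COc1ccc(S(=O)(=O)Oc2ccccc2/C=C(\C#N)C(=O)Nc2nnc(-c3cccs3)s2)cc1` gives 67% and stands level with compound 3 `Cc1ccc(S(=O)(=O)Oc2cccc(/C=C(\C#N)C(=O)Nc3nnc(C)s3)c2)cc1` at 71% within the scatter, while compound 2 `N#C/C(=C\c1ccccc1OS(=O)(=O)c1ccc([N+](=O)[O-])cc1)C(=O)Nc1nnc(-c2cccs2)s1` reaches only 23% and lies clearly lower. Compound 4 `COc1ccc(S(=O)(=O)Oc2ccccc2/C=C(\C#N)C(=O)Nc2nnc(Cc3ccc(F)cc3)s2)cc1` keeps the core of compound 1 and changes one group (4-fluorobenzyl in place of thiophen-2-yl on an aromatic carbon) so that 4-fluorobenzyl stands in place of thiophen-2-yl on an aromatic carbon. For the measured compounds named here, the only measured step with a single change is large (a number 44 percentage points lower from compound 1 to compound 2 (beyond the scatter)) but concerns a different group, so it shows that one swap can move this number far without saying how this swap will act. Compound 1 and compound 3 differ in more than one place, the thiophen-2-yl among them, yet their values lie within the scatter of each other, which is a weak hint against a large loss. Going by the values given here, no measured step covers this exact change, so a small drop is expected (a number 7 percentage points lower from compound 1 to compound 4 (within the scatter)) and the range is kept wide. Compound 4 is expected at 60% with an estimated range from 35% to 82% as the likely span.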

Compound 4, percent growth inhibition at one concentration: 100%
Beside the measured number, compound 4's estimate is 40 percentage points below it; the measured number lies above the stated range.
By their numbers in this assay, from the lowest: compound 2; then compounds 1 and 3 (each within the scatter of the next); then compound 4.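

At this place, on the aromatic carbon next to the ring sulfur, the swap to 4-fluorobenzyl gives a number 33 percentage points higher from compound 1 to compound 4 (beyond the scatter) in this assay, so this position can move the number strongly and upward, and a six-membered carbon-only ring is accepted here in place of the thiophen-2-yl. Compound 4 at 100% stands at the top of this percentage scale, so one tested concentration cannot show how much further its activity reaches. Nothing measured here explains the gain.

As far as these compounds go, whether the gain goes with the fluorine, the carbon-only ring or the carbon link that joins it to the core stays open. A plain benzyl, a phenyl or a longer 2-phenylethyl chain at this place would pull these parts apart.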